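From fluoro to trifluoromethyl in an antiproliferative series

This account rests on a few compounds, and the source may have more. Where it says the series, first, only, none or still open, it means among the compounds named here.

compound 1 (`COc1ccc(CN(C(=O)CSc2nc3ccccc3s2)c2cc(OC)c(OC)c(OC)c2)cc1C`): 34300 nM
compound 2 (`COc1ccc(CN(C(=O)CSc2nc3ccccc3s2)c2cc(OC)c(OC)c(OC)c2)cc1F`): 20100 nM
compound 3 (`COc1ccc(CN(C(=O)CSc2nc3ccccc3s2)c2cc(OC)c(OC)c(OC)c2)cc1C(F)(F)F`): not yet measured

Going by the values given here, in a functional assay on PC-3 cells (Homo sapiens) for antiproliferative activity, read by MTT assay, with a stated time of 48 h (a lower number here means a stronger inhibitor, a higher number a weaker inhibitor), compound 2 gives 20100 nM and has only one measured neighbour to compare with. Among the compounds with values here, the single measured step, fluoro in place of methyl on an aromatic carbon, is a 1.7-fold lower number from compound 1 to compound 2 (0.23 log units; within the scatter) and so does not separate the two. The next change is at that same carbon, ortho to a methoxy group, with trifluoromethyl in place of fluoro on an aromatic carbon. Within the data shown here, no measured compound carries trifluoromethyl, so the small step already seen is the only guide. No step beyond the scatter is therefore expected in this assay, in either direction. The estimated change is a 1.2-fold higher number from compound 2 to compound 3 (0.09 log units; within the scatter) and it remains an expectation only. Compound 3 is expected at 25000 nM (estimated range 11000 nM to 55000 nM).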

Compound 3, half-maximal inhibitory concentration: > 80000 nM
Compound 3: no number, only a limit (the forecaster's own chance of this, stated with the estimate: 10%); middle value at least 3.2-fold (0.50 log units) from the limit.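

In this assay, compound 3 gives > 80000 nM, which is a limit and not a number: the limit of > 80000 nM in this assay, at which 1 of the 3 values shown sits.

Methyl and fluoro at this carbon had read within the scatter of each other, so the position could have seemed insensitive to what sits on it. Trifluoromethyl shows that it is not, with an at least 3.9-fold higher number from compound 2 to compound 3 (0.59 log units; beyond the scatter) and an at least 2.3-fold higher number from compound 1 to compound 3 (0.36 log units; beyond the scatter), both towards weaker inhibition and both minimum sizes, so this is the first change here that clearly moves the number.

What the three compounds cannot say is which feature of trifluoromethyl matters, or how far the true value lies past the limit. Going by these compounds, how an amine, a carboxylic acid or plain hydrogen on this carbon would read also remains open.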